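The source may report more compounds than this note shows. Statements on the series, on what has been measured and on what is new or still open speak of the compounds shown alone.

Of the compounds shown here, three have so far been tested in a functional assay on the whole organism for inhibition, with Brassica rapa subsp. chinensis as the target, with a stated time of 3 days, tested at 100 ppm; on this read-out lower numbers stand for less inhibition of growth and higher numbers for more inhibition of growth at the one concentration tested. Compound 1 (`CCCCCNC(=O)/C=C/c1ccccc1`) gives 60%, the highest number of the three. Compound 2 (`C=CCc1ccc(OC(=O)/C=C/c2ccc(C(C)C)cc2)c(OC)c1`) gives 40%, and compound 3 (`CC(C)c1ccc(/C=C/C(=O)OCCOc2ccccc2)cc1`) gives 32%. The gaps down from compound 1 to each of these two lie beyond the usual scatter of such measurements. Neither of them differs from compound 1 in a single place, however, so these numbers do not isolate the effect of any one structural change.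

Compound 4 (`CCCNC(=O)/C=C/c1ccccc1`) has not yet been measured. It departs from compound 1 in one place: hydrogen in place of ethyl on a saturated chain carbon, three bonds along the chain from an amide-type nitrogen. This is hydrogen in place of ethyl on a saturated chain carbon, three bonds along the chain from an amide-type nitrogen, and the same difference reads as pentyl to propyl. Among the measured compounds shown here, no measured pair shows what such a change does, so the expectation starts from the value of compound 1, 60%, and allows for considerable uncertainty. A small fall that stays within the scatter is expected, with the estimated change being a number 8 percentage points lower from compound 1 to compound 4 (within the scatter). In this assay the expected value for compound 4 is 52%, with an estimated range from 32% to 70%.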

Compound 4, percent growth inhibition at one concentration: 15%
Compound 4: middle estimate off by 37 percentage points, on the high side; the measured number lies below the stated range.
By their numbers in this assay, from the lowest: compound 4; then compounds 3 and 2 (each within the scatter of the next); then compound 1.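

In this assay, among the compounds shown here, the single change from pentyl to propyl gives a number 45 percentage points lower from compound 1 to compound 4 (beyond the scatter) and is the only comparison so far that isolates one structural difference. It shows that this position on the saturated chain is not indifferent: with the rest of the structure held the same, removing the ethyl portion of the pentyl chain costs much of the growth inhibition, something compound 2 and compound 3 could not show because neither differs from compound 1 in one place only. Nothing shown gives a measured reason for the size of this step, so it stands as an observation without an explanation.

With only pentyl and propyl compared, the compounds shown leave open whether the response falls gradually or abruptly along the chain, and butyl would help to settle that. They also leave open whether a longer chain, such as hexyl or octyl, would raise growth inhibition further or lower it, and whether a branched chain or a terminal amine or carboxylic acid could take the place of the chain end.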